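This account rests on a few compounds, and the source may have more. Where it says the series, first, only, none or still open, it means among the compounds named here.

Working notes on the series in an assay on MCF7 cells for inhibition of Serine-protein kinase ATM (Homo sapiens), read by immunofluorescence, with a stated time of 1 h; a lower number here means a stronger inhibitor, a higher number a weaker inhibitor.

Compound 1 `Nc1nc(-c2ccccn2)nn1-c1ncnc2cc(OC(F)(F)F)ccc12` reaches only the limit of the assay: in this assay compound 1 gives > 40000 nM, which is a limit rather than a number. Compound 2 `CCN(CC)c1nc(-n2nc(-c3ccccn3)nc2N)c2cc(OC)c(OC)cc2n1` also sits at that limit, and in this assay compound 2 gives > 40000 nM. Going by the values given here, compound 3 `COc1cc2ncnc(-n3nc(-c4ccccn4)nc3N)c2cc1OCCCNC(=O)CN1C[C@@H](C)O[C@@H](C)C1` is the only member of the set with a measured number: in this assay compound 3 gives 1700 nM. It therefore stands alone on the numbers shown, the other two values being (the limit of > 40000 nM in this assay, at which 2 of the 3 values shown sit).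

Compound 4 `COc1cc2ncnc(-n3nc(-c4ccccn4)nc3N)c2cc1OCCCNC(=O)OCC(C)(C)C` is not yet measured. It differs from compound 3 in one place: neopentyloxy in place of (2,6-dimethylmorpholin-4-yl)methyl on a carbonyl carbon whose other neighbour is an amide-type nitrogen. Among the compounds with values here, no pair of measured compounds differs in a single place, so no measured step sets the size of such a change here, and the two limits give no direction either.

The expectation for compound 4 is a step of a 1.5-fold higher number from compound 3 to compound 4 (0.17 log units; within the scatter), modest and toward weaker inhibition, with wide uncertainty. Compound 4 is estimated at 2500 nM, with a range from 800 nM to 8000 nM.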

Compound 4, half-maximal inhibitory concentration: 1900 nM
Compound 4: middle estimate off by 1.3-fold (0.12 log units), on the high side, and the stated range covers the measured number.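

Replacing (2,6-dimethylmorpholin-4-yl)methyl with neopentyloxy on a carbonyl carbon whose other neighbour is an amide-type nitrogen gives, in this assay, a 1.1-fold higher number from compound 3 to compound 4 (0.05 log units; within the scatter). Going by these compounds alone, this is the first single-place step, and it shows that the value at this position holds within the scatter when the six-membered non-aromatic ring, with its nitrogen and two defined stereocentres, gives way to a group with no ring and fewer heavy atoms. No measurement shown bears on why the two groups read alike here, so the step records tolerance for this one exchange and gives no cause.

Within the data shown here, two groups that differ this much in shape and atoms give only one comparison, so it remains open whether a primary amine or a carboxylic acid at this carbonyl carbon, or methyl as a much smaller group, would leave the value unchanged. Also open, from the compounds shown here alone, is whether the carbonyl itself matters, which a sulfonyl in its place would test, and whether a longer chain carrying the neopentyloxy group would shift the number beyond the scatter.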